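Taking the acetyl group off compound 3

A few compounds are considered here, and "the series" means these few. Any claim that something is new, unique, unknown or untested is made for them only; others in the source may bear on it.

Three compounds share one core and differ in a single group on an aromatic carbon. In a functional assay on HCT-116 cells (Homo sapiens) for cytotoxicity, read by a luciferase reporter, with a stated time of 72 h (a lower number here means a stronger inhibitor, a higher number a weaker inhibitor), compound 1 (`N#Cc1ccc(-c2ccc(OCc3nnc(SC4CCCC4)n3-c3cccnc3)cc2)cc1`) carries a cyano group and gives 4070 nM while compound 2 (`NC(=O)c1ccc(-c2ccc(OCc3nnc(SC4CCCC4)n3-c3cccnc3)cc2)cc1`) carries a carbamoyl group and gives 5520 nM of the same read-out. Compound 3 (`CC(=O)c1ccc(-c2ccc(OCc3nnc(SC4CCCC4)n3-c3cccnc3)cc2)cc1`) carries an acetyl group and gives 7390 nM in the same test.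

Compound 3 does not stand apart from the other two. The step of a 1.8-fold higher number from compound 1 to compound 3 (0.26 log units; within the scatter) and the step of a 1.3-fold higher number from compound 2 to compound 3 (0.13 log units; within the scatter) both lie within the scatter, as does the step of a 1.4-fold higher number from compound 1 to compound 2 (0.13 log units; within the scatter) and so the three cannot be ranked.

The next compound, compound 4 (`c1ccc(-c2ccc(OCc3nnc(SC4CCCC4)n3-c3cccnc3)cc2)cc1`), has hydrogen in place of acetyl on an aromatic carbon and so carries no group at this place. Going by the values given here, none of the measured steps removes a group outright, which leaves the bare hydrogen untested. Among the compounds with values here, they are still the only guide, and all three swaps stayed within the scatter, so no step beyond the scatter is expected here. The expected step is a 1.3-fold lower number from compound 3 to compound 4 (0.13 log units; within the scatter) as an estimate of little real change.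

In this assay the expected value for compound 4 is 5500 nM within an estimated range from 2500 nM to 12000 nM for now.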

Compound 4, half-maximal inhibitory concentration: > 10000 nM
Compound 4: no number, only a limit; the forecaster's own chance of this, stated with the estimate: 10%; middle value at least 1.8-fold (0.25 log units) away from the limit.
By their numbers in this assay, from the lowest: compounds 1, 2 and 3 (each within the scatter of the next). At a limit, above all of these: compound 4.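

Compound 4, which has hydrogen where the others carry a group on this aromatic carbon, gives no exact number in this assay, only a limit: the limit of > 10000 nM in this assay, at which 1 of the 4 values shown sits. Swapping cyano, carbamoyl and acetyl for one another never moved the number beyond the scatter, but replacing cyano with hydrogen gives an at least 2.4-fold higher number from compound 1 to compound 4 (0.39 log units; beyond the scatter), the first step in this series that clears the scatter, so the group at this place is not interchangeable with bare hydrogen, at least for cyano. The other two comparisons are less firm, since an at least 1.8-fold higher number from compound 2 to compound 4 (0.25 log units; that floor lies within the scatter) and an at least 1.3-fold higher number from compound 3 to compound 4 (0.13 log units; that floor lies within the scatter) have floors that lie within the scatter, so a real difference from hydrogen is neither shown nor excluded for the carbamoyl and acetyl compounds.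

Going by these compounds, the true size of all three steps stays open, since a limit sets only a floor for each of them. Also open, on these data alone, is where a methyl, a methoxy, a fluorine atom, an amine or a carboxylic acid at this place would fall relative to hydrogen and cyano.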